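The source may report more compounds than this note shows. Statements on the series, on what has been measured and on what is new or still open speak of the compounds shown alone.

Compound 1 `O=c1ccn([C@@H]2O[C@H](COP(=O)(O)O)[C@@H](O)[C@H]2O)c(SCCc2ccccc2)n1` in an in vitro functional assay on 1321-N1 cells for agonist activity at P2Y purinoceptor 6 (Homo sapiens), read by scintillation proximity assay and inositol phosphate accumulation; on this read-out higher numbers stand for an effect only at larger amounts of compound and lower numbers for an effect already at smaller amounts: > 100000 nM, a limit of the assay rather than a number.
Compound 2 `CCCSc1nc(=O)ccn1[C@@H]1O[C@H](COP(=O)(O)OP(=O)(O)O)[C@@H](O)[C@H]1O` in this assay: >= 100000 nM, likewise a limit of the assay.

Compound 1 therefore stands at the limit of this assay, and compound 2 does the same, so these two values show no difference between them that could be read as a step. Compound 3 `O=c1ccn([C@@H]2O[C@H](COP(=O)(O)O)[C@@H](O)[C@H]2O)c(SCc2ccccc2)n1` has not yet been measured. It differs from compound 1 by phenyl in place of benzyl on a saturated chain carbon bound to a sulfur; cut one bond further out, the same difference reads phenethyl to benzyl, or phenethylsulfanyl to benzylsulfanyl. Among the measured compounds shown here, no step between measured compounds is available to lean on, so the expected step is a step that the limit leaves unreadable from compound 1 to compound 3, nothing beyond the usual scatter, and most likely the result will again be reported only as a limit. Compound 3 is accordingly estimated at 150000 nM, with a likely range from 30000 nM to 1000000 nM.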

Compound 3, half-maximal effective concentration: > 100000 nM
Compound 3: only a limit was reported; the forecaster's own chance of this, stated with the estimate: 85%; the middle value does not contradict the limit.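

Compound 1 and compound 3 both stop at a limit of this assay rather than at a number, so no step can be read between them. On these data alone, whether phenethylsulfanyl and benzylsulfanyl differ in effect stays open, as does what would give a readable number on this core.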